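This account rests on a few compounds, and the source may have more. Where it says the series, first, only, none or still open, it means among the compounds named here.

Measured in this assay (a functional assay on HCT-116 cells (Homo sapiens) for antiproliferative activity, read by MTT assay, with a stated time of 48 h; on this read-out lower numbers stand for stronger inhibition and higher numbers for weaker inhibition):

- compound 1 (`CCCCCCCC(CCO)n1cnc2c(Cl)nc(F)nc21`) gives 17600 nM
- compound 2 (`CCCCCCCC(CCO)n1cnc2c(Cl)ncnc21`) gives 4160 nM
- compound 3 (`CCCCCCC[C@H](CCO)n1cnc2c(Cl)ncnc21`) gives 2670 nM

Compound 2 stands within the scatter of compound 3, and its number lies clearly lower than that of compound 1. Compound 4 (`CCCCCCCC(CCO)n1cnc2c(NC)ncnc21`) differs from compound 2 in one place, with methylamino in place of chloro on an aromatic carbon. Within the data shown here, no measured step touches this chloro. The stereo step (a 1.6-fold lower number from compound 2 to compound 3 (0.19 log units; within the scatter)) concerns only a saturated chain carbon, so it offers little guidance. The nearest guide is a swap on an aromatic carbon of the shared core (a 4.2-fold lower number from compound 1 to compound 2 (0.63 log units; beyond the scatter)), which was modest. A step of similar size towards weaker inhibition is therefore expected (a 3.6-fold higher number from compound 2 to compound 4 (0.56 log units; beyond the scatter)), though this direction is uncertain. Compound 4 is expected at 15000 nM (estimated range 5000 nM to 50000 nM).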

Compound 4, half-maximal inhibitory concentration: 12500 nM
For compound 4 the middle estimate is 1.2-fold (0.08 log units) above the measured one; measured number inside the range.
By their numbers in this assay, from the lowest: compounds 3 and 2 (each within the scatter of the next); then compounds 4 and 1 (each within the scatter of the next).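

Replacing the chloro with methylamino gives a 3.0-fold higher number from compound 2 to compound 4 (0.48 log units; beyond the scatter), and a higher number here means weaker inhibition. Among these compounds, this is the first evidence that the position can't take this change without a loss, whereas the earlier steps touched only the fluoro site on the shared core and the chain carbon. Nothing shown here accounts for the size of this step. Going by these compounds, it remains open whether a plain amino group, a dimethylamino group or a methoxy group at this position would do better or worse than chloro. Also open, on these data alone, is whether methylamino would cost as much on compound 3, the form with a defined configuration.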